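This account rests on a few compounds, and the source may have more. Where it says the series, first, only, none or still open, it means among the compounds named here.

For the measured compounds named here, in a functional assay on A549 cells (Homo sapiens) for cytotoxicity, read by MTT assay, with a stated time of 72 h (on this read-out higher numbers stand for weaker inhibition and lower numbers for stronger inhibition), compound 1 `COc1cc(/C=C/C=O)cc(OC)c1OC/C=C(\C)CCC=C(C)C` gives 71000 nM and stands level, within the scatter, with compound 2 `COc1cc(/C=C/C=O)cc(OC)c1OCC=C(C)C` at 68000 nM as the only other number so far. Going by the values given here, the one measured step is a 1.0-fold lower number from compound 1 to compound 2 (0.02 log units; within the scatter) and it alters only the side chain. Compound 3 `COc1cc(/C=C/C=O)ccc1OC/C=C(\C)CCC=C(C)C` keeps the side chain of compound 1 and carries hydrogen in place of methoxy on an aromatic carbon as its change, hydrogen in place of methoxy on an aromatic carbon. Among the compounds with values here, no measured step touches that methoxy, so the data give neither size nor direction for this change directly. Resting on compound 2 at 68000 nM as the only, indirect guide, no step beyond the scatter is expected in this assay for this change, with wide uncertainty. The expected step is a 1.0-fold lower number from compound 1 to compound 3 (0.01 log units; within the scatter) on this estimate. For compound 3 the estimated value is 70000 nM with an expected range from 30000 nM to 160000 nM on repeat measurement.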

Compound 3, half-maximal inhibitory concentration: 5000 nM
Compound 3: the middle estimate sits 14-fold (1.15 log units) above what was measured; measured number below the stated range.
By their numbers in this assay, from the lowest: compound 3; then compounds 2 and 1 (each within the scatter of the next).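

In this assay, hydrogen in place of methoxy on the aromatic carbon gives a 14-fold lower number from compound 1 to compound 3 (1.15 log units; beyond the scatter), with the side chain left unchanged. For the compounds shown here, the only earlier step, a 1.0-fold lower number from compound 1 to compound 2 (0.02 log units; within the scatter), altered the side chain alone and stayed within the scatter, so this aromatic carbon is the first place where a single change moves the number beyond the scatter. Nothing available bears on why the number falls at this position.

From the compounds shown here alone, whether the same replacement gives a step of similar size with the side chain of compound 2 stays open. Also open, going by these compounds, is whether hydrogen itself is needed on this aromatic carbon, or whether a hydroxy group, a fluorine atom or an amine there would give a number close to that of compound 3.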